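Methyl to Chloro: An Expected Outcome for Compound 4

This account rests on a few compounds, and the source may have more. Where it says the series, first, only, none or still open, it means among the compounds named here.

compound 1 `COc1ccc(C2=NN(c3ccccc3)C(c3ccc(C)cc3)C2S(=O)(=O)CC2=NCCS2)cc1`: 39.4%
compound 2 `Cc1ccc(C2CNN=C2S(=O)(=O)CC2=NCCS2)cc1`: 43.1%
compound 3 `Cc1ccc(C2CNN=C2S(=O)(=O)CC2=NCCO2)cc1`: 45.9%

In a functional assay, read by Griess assay, with a stated time of 150 min, tested at 50 ug/mL (on this read-out higher numbers stand for a stronger effect at the one concentration tested and lower numbers for a weaker effect), compound 2 stands in the middle of the three numbers, which all lie within the scatter of one another. Compound 4 `O=S(=O)(CC1=NCCS1)C1=NNCC1c1ccc(Cl)cc1` differs from compound 2 by chloro in place of methyl on an aromatic carbon. Among the compounds with values here, no measured step contains this exchange; the only measured step, a number 2.8 percentage points higher from compound 2 to compound 3 (within the scatter), concerns a different part of the molecule and stays within the scatter. Within the data shown here, nothing among the measured compounds points to a shift in either direction, so compound 4 is expected to land near compound 2, with a number 0.1 percentage points lower from compound 2 to compound 4 (within the scatter) in this assay. The estimate for compound 4 in this assay is 43%, expected to fall between 30% and 56%.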

Compound 4, a percentage reported as activity, at one concentration (the size of the read-out at that concentration, not a potency): "not active" (no number reported)
Compound 4: no number reported; no gap can be computed for the estimate.
By their numbers in this assay, from the lowest: compounds 1, 2 and 3 (each within the scatter of the next).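

Within the data shown here, compound 4 is reported as "not active" with no number, so no step from compound 2 to compound 4 can be read. Nothing measured here bears on this result. The compounds shown leave open how 4-chlorophenyl in place of 4-methylphenyl changes the effect.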